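Second Fluorine on the Amide Aryl Ring

This account rests on a few compounds, and the source may have more. Where it says the series, first, only, none or still open, it means among the compounds named here.

The compounds measured so far:
Compound 1 `O=C(Nc1cccc(-c2oc3cc(-c4ccc(F)cc4)ccc3c(=O)c2O)c1)c1ccc(Br)cc1` gives 8630 nM in a functional assay on HCC1937 cells (Homo sapiens) for antiproliferative activity, read by CCK-8 assay, with a stated time of 72 h; a higher number here means a weaker inhibitor, a lower number a stronger inhibitor.
Compound 2 `COc1cccc(C(=O)Nc2cccc(-c3oc4cc(-c5ccc(F)cc5)ccc4c(=O)c3O)c2)c1` gives 18900 nM in this assay.
Compound 3 `O=C(Nc1cccc(-c2oc3cc(-c4ccc(F)cc4)ccc3c(=O)c2O)c1)c1cccc(F)c1` gives 6590 nM in this assay.

All three share one core and differ only in the ring attached to the carbonyl of the amide. Compound 3, with a 3-fluorophenyl there, has the lowest number of the three: the two steps that lead to it are a 1.3-fold lower number from compound 1 to compound 3 (0.12 log units; within the scatter) and a 2.9-fold lower number from compound 2 to compound 3 (0.46 log units; beyond the scatter). Replacing the 4-bromophenyl of compound 1 by 3-methoxyphenyl gave a 2.2-fold higher number from compound 1 to compound 2 (0.34 log units; beyond the scatter).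

Compound 4 `O=C(Nc1cccc(-c2oc3cc(-c4ccc(F)cc4)ccc3c(=O)c2O)c1)c1cc(F)cc(F)c1` differs from compound 3 by fluoro in place of hydrogen on an aromatic carbon. Among the measured compounds shown here, no measured step adds a second substituent to this ring; the nearest evidence is the exchange of one group for another, where the bromo-to-fluoro step stayed within the scatter and only the methoxy stood apart. A second fluoro, placed meta to the first, is therefore expected to leave the number close to that of compound 3, with no step beyond the scatter: the expected step is a 1.1-fold lower number from compound 3 to compound 4 (0.04 log units; within the scatter). Compound 4 is estimated at 6000 nM, with a range from 2500 nM to 14000 nM.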

Compound 4, half-maximal inhibitory concentration: 2070 nM
Estimate against measurement, compound 4: 2.9-fold (0.46 log units) above, and the stated range ends above it.
By their numbers in this assay, from the lowest: compound 4; then compounds 3 and 1 (each within the scatter of the next); then compound 2.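

In this assay, among the compounds shown here, adding a second fluoro to the amide aryl ring gave a 3.2-fold lower number from compound 3 to compound 4 (0.50 log units; beyond the scatter), the first step here that adds a substituent to this ring rather than exchanging one group for another, and it lies beyond the scatter. The 3,5-difluorophenyl ring also separates clearly from the other two rings measured at this position, with a 4.2-fold lower number from compound 1 to compound 4 (0.62 log units; beyond the scatter) and a 9.1-fold lower number from compound 2 to compound 4 (0.96 log units; beyond the scatter), whereas the exchange between the 4-bromophenyl and 3-fluorophenyl rings stayed within the scatter, so a single atom entering at this place can matter more than that larger exchange of rings did. No measurement shown here bears on why this one added fluoro produces a step of this size.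

With only one doubly substituted ring among these compounds, it remains open whether the lower number depends on fluoro itself or would also follow from another second group at the same place, such as chloro, methyl or nitrile. Going by these compounds, it is equally open how an amine or a carboxylic acid on this ring would compare with the 3,5-difluorophenyl ring.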